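Fluoro added ortho to chloro in compound 3

This account rests on a few compounds, and the source may have more. Where it says the series, first, only, none or still open, it means among the compounds named here.

Compound 1 `O/N=C(/Nc1ccccc1)c1ccc2occc2c1` gives 19000 nM in an assay on tissue (HeLa cells) for inhibition of Indoleamine 2,3-dioxygenase 1 (Homo sapiens), read by spectrophotometry; on this read-out lower numbers stand for stronger inhibition and higher numbers for weaker inhibition. Compound 2 `O/N=C(/Nc1ccc(Cl)cc1)c1ccc2occc2c1` is the chloro analogue of compound 1. In this assay compound 2 reaches only the limit of > 30000 nM, so no number is known for it. The step of an at least 1.5-fold higher number from compound 1 to compound 2 (0.19 log units; that floor lies within the scatter) thus rests on a limit, compound 2 sitting at the limit of > 30000 nM in this assay, at which 1 of the 2 values shown sits. Compound 3 `O/N=C(/Nc1ccc(Cl)c(F)c1)c1ccc2occc2c1` differs from compound 2 by fluoro in place of hydrogen on an aromatic carbon, the fluoro entering ortho to a chloro group and meta to a large group. Among the measured compounds shown here, only the step from compound 1 to compound 2 bears on this change; it points towards weaker inhibition, and its true size is unknown. Compound 2 already stands at a limit. For compound 3 the expected step that the limit leaves unreadable from compound 2 to compound 3 is none beyond the scatter. Compound 3 is estimated at 40000 nM, within 15000 nM to 120000 nM in this assay, most likely again reported only as a limit.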

Compound 3, half-maximal inhibitory concentration: 10300 nM
Compound 3: the middle estimate sits 3.9-fold (0.59 log units) above what was measured; the whole stated range lies above it.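

In this assay, among the compounds shown here, the change gives an at least 2.9-fold lower number from compound 2 to compound 3 (0.46 log units; beyond the scatter), so fluoro in place of hydrogen on this aromatic carbon, ortho to a chloro group and meta to a large group, moves the value towards stronger inhibition, the opposite direction to the one the chloro step had pointed. Compound 2 gives > 30000 nM, which is a limit and not a number. The true size of the step stays unknown and only its floor can be read, because compound 2 stands at that limit: the limit of > 30000 nM in this assay, at which 1 of the 3 values shown sits.

As far as these compounds go, whether fluoro has the same effect without the chloro group remains open. Also open, from the compounds shown here alone, is whether another group on this carbon, such as methoxy, an amine or a carboxylic acid, would shift the value in the same direction.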